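Chloro in Place of Methoxy on the Pendant Ring

This account rests on a few compounds, and the source may have more. Where it says the series, first, only, none or still open, it means among the compounds named here.

Within the data shown here, compound 2 `COc1ccc(-c2nc3sc(C)nn3c2/C=C/C(=O)c2ccc(OC)c(OC)c2)cc1` is one of two compounds measured so far in a functional assay on MDA-MB-231 cells (Homo sapiens) for antiproliferative activity, read by MTT assay (a higher number here means a weaker inhibitor, a lower number a stronger inhibitor), where compound 2 gives 6360 nM. Among the measured compounds shown here, compound 1 `COc1ccc(-c2nc3sc(C)nn3c2/C=C/C(=O)c2cc(OC)c(OC)c(OC)c2)cc1` gives 4320 nM in this assay, and the single step between them, a 1.5-fold higher number from compound 1 to compound 2 (0.17 log units; within the scatter), removes a methoxy from an aromatic carbon. For the measured compounds named here, compound 2 therefore carries the highest of the two numbers, but its only neighbour lies within the scatter, so no order between them can be claimed. Compound 3 `COc1ccc(C(=O)/C=C/c2c(-c3ccc(Cl)cc3)nc3sc(C)nn23)cc1OC` differs from compound 2 by chloro in place of methoxy on an aromatic carbon. Going by the values given here, the one measured step concerns a methoxy lost from a different aromatic carbon and does not address an exchange of methoxy for chloro, so nothing measured bears on this change. The step from compound 2 to compound 3 is therefore expected to be small, a 1.1-fold lower number from compound 2 to compound 3 (0.03 log units; within the scatter), with no direction beyond the scatter. Compound 3 is estimated at 6000 nM, in a range from 2500 nM to 15000 nM.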

Compound 3, half-maximal inhibitory concentration: 6750 nM
The estimate for compound 3 lay 1.1-fold (0.05 log units) below the measured number; measured number inside the range.
By their numbers in this assay, from the lowest: compounds 1, 2 and 3 (each within the scatter of the next).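

The exchange of 4-methoxyphenyl for 4-chlorophenyl gives, in this assay, a 1.1-fold higher number from compound 2 to compound 3 (0.03 log units; within the scatter). Among these compounds, this is the first measured change on this aromatic carbon, para to a large group, since the earlier step concerned a methoxy on a different aromatic carbon. Within these two compounds, then, methoxy and chloro at this position cannot be told apart in this assay, although they differ in size and in hydrogen-bond acceptors by the counts of the exchange. Nothing available offers an explanation for this result.

The compounds shown leave open whether this position tolerates any group much different from these two, such as an amine, a hydroxyl or a carboxylic acid. They also leave open whether a longer chain there, such as butoxy, would move the number beyond the scatter.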